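A few compounds are considered here, and "the series" means these few. Any claim that something is new, unique, unknown or untested is made for them only; others in the source may bear on it.

Compound 2 `CC1(C)CCN(S(=O)(=O)c2ccc(NC(=O)c3ccc([N+](=O)[O-])s3)cc2)CC1` and compound 1 `CC1(C)CCN(S(=O)(=O)c2ccc(NC(=O)c3ccc([N+](=O)[O-])o3)cc2)CC1` share one core and differ in a single place: 5-nitrofuran-2-yl in place of 5-nitrothiophen-2-yl on a carbonyl carbon. In an ADME assay on IMR-90 cells (Homo sapiens) for cytotoxicity, read by CellTiter-Blue, with a stated time of 46 h (on this read-out lower numbers stand for an effect already at smaller amounts and higher numbers for an effect only at larger amounts of compound), compound 2 returns only a limit, > 25000 nM. Compound 1 likewise returns only a limit in this assay, > 25000 nM. The step that the two limits leave unreadable from compound 2 to compound 1 therefore cannot be sized. Compound 3 `CC1(C)CCN(S(=O)(=O)c2cccc(NC(=O)c3ccc([N+](=O)[O-])s3)c2)CC1` is built from the same atoms as compound 2, joined differently; the difference between the two cores is not broken down here. In this assay compound 3 also gives only a limit, > 25000 nM. Compound 4 `CC1(C)CCN(S(=O)(=O)c2cccc(NC(=O)c3ccc([N+](=O)[O-])o3)c2)CC1` stands to compound 3 as compound 1 stands to compound 2, the same change at the same place: 5-nitrofuran-2-yl in place of 5-nitrothiophen-2-yl on a carbonyl carbon. Among the compounds with values here, since every value so far sits at the limit of > 25000 nM in this assay, at which 3 of the 3 values shown sit, the step from compound 3 to compound 4 is expected to stay unreadable in the same way, a step that the limit leaves unreadable from compound 3 to compound 4. Compound 4 is accordingly expected to give 30000 nM, most probably reported once more as a limit rather than a number.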

Compound 4, half-maximal effective concentration: > 25000 nM
Compound 4 ended at the assay's limit; the forecaster's own chance of this, stated with the estimate: 85%; the middle value is on the limit's open side.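

Compound 3 and compound 4 both return only a limit, so no step can be read between them. The compounds shown leave open whether exchanging 5-nitrothiophen-2-yl for 5-nitrofuran-2-yl changes the read-out at all.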